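Methyl to trifluoromethyl on the benzyl ring, two cores

The compounds below may be only part of what the source reports. "The series", "measured", "known", "first", "only" and "open" are said of these compounds alone.

Compound 1 `Cc1cc(=O)oc2cc(SCc3cccc(C(F)(F)F)c3)ccc12` and compound 2 `Cc1cccc(CSc2ccc3c(C)cc(=O)oc3c2)c1` share one core; compound 3 `CCc1cc(=O)c2ccc(OCc3cccc(C)c3)c(C)c2o1` and compound 4 `CCc1cc(=O)c2ccc(OCc3cccc(C(F)(F)F)c3)c(C)c2o1` share another, and the difference between the two cores is not broken down here. In a functional assay on KB cells (Homo sapiens) for antiproliferative activity, read by sulforhodamine B assay, with a stated time of 72 h (a lower number here means a stronger inhibitor of growth, a higher number a weaker inhibitor of growth), compound 1 gives only a limit, > 28500 nM, recorded as the limit of > 28500 nM in this assay, at which 1 of the 3 values shown sits. Compound 2 in this assay also gives only a limit, > 33700 nM, recorded as the limit of > 33700 nM in this assay, at which 1 of the 3 values shown sits. Within the data shown here, compound 3 in this assay gives 28600 nM, the one number among the three measured values.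

The change from compound 2 to compound 1 is trifluoromethyl in place of methyl on an aromatic carbon. The step that the two limits leave unreadable from compound 2 to compound 1 cannot be read, as both ends are limits. The change from compound 3 to compound 4 is trifluoromethyl in place of methyl on an aromatic carbon, the same kind of change on the other core, at a place described in the same words.

With no readable precedent, compound 4 is expected to stay close to compound 3, the estimated step being a 1.0-fold higher number from compound 3 to compound 4 (0.02 log units; within the scatter). This expectation rests on the unreadable step that the two limits leave unreadable from compound 2 to compound 1 and on the measured value of compound 3, which gives 28600 nM. Compound 4 is therefore estimated at 30000 nM in this assay, expected between 12000 nM and 80000 nM, with a fair chance that only a limit is reported.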

Compound 4, concentration for 50% growth inhibition: > 27600 nM
Compound 4 was reported as a limit (the forecaster's own chance of this, stated with the estimate: 45%); the middle value is on the limit's open side.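

In this assay compound 4 gives > 27600 nM, a limit and not a number. With that limit, no size can be read for the change from compound 3 to compound 4. The compounds shown leave open whether trifluoromethyl in place of methyl on an aromatic carbon changes growth inhibition at all on either core.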